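From methoxycarbonyl to carboxy: what compound 3 may show

The compounds below may be only part of what the source reports. "The series", "measured", "known", "first", "only" and "open" are said of these compounds alone.

In a functional assay on K562 cells (Homo sapiens) for antiproliferative activity, read by MTT assay, with a stated time of 48 h (a higher number here means a weaker inhibitor, a lower number a stronger inhibitor), compound 1 `CC[C@@H](C)[C@H](NC(=O)c1ccc(Oc2nc3ccccc3nc2C)cc1)C(=O)OC` gives 38300 nM and compound 2 `CC[C@@H](C)[C@H](NC(=O)c1ccc(Oc2nc3ccccc3nc2NC(C)(C)C)cc1)C(=O)OC` gives 38700 nM as its value. For the measured compounds named here, compound 2 thus sits within the scatter of the only other measured compound. Going by the values given here, the one measured step is a 1.0-fold higher number from compound 1 to compound 2 (0.00 log units; within the scatter) and comes from (tert-butyl)amino in place of methyl on an aromatic carbon. Compound 3 `CC[C@@H](C)[C@H](NC(=O)c1ccc(Oc2nc3ccccc3nc2NC(C)(C)C)cc1)C(=O)O` keeps that group and differs elsewhere, by hydrogen in place of methyl on an oxygen next to a carbonyl group in a change of methoxycarbonyl to carboxy. Among the compounds with values here, no measured step touches this place, so the data offer neither a size nor a direction for it, and the range must stay wide. The expected change is therefore none beyond the scatter, and the estimate means a 1.2-fold higher number from compound 2 to compound 3 (0.07 log units; within the scatter) as its step. For compound 3 the estimated value is 45000 nM with an expected range from 18000 nM to 100000 nM in this measurement.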

Compound 3, half-maximal inhibitory concentration: 18300 nM
Compound 3: the middle estimate sits 2.5-fold (0.39 log units) above what was measured, and the stated range covers the measured number.
By their numbers in this assay, from the lowest: compound 3; then compounds 1 and 2 (each within the scatter of the next).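

In this assay, for the compounds shown here, the change of methoxycarbonyl to carboxy gives a 2.1-fold lower number from compound 2 to compound 3 (0.33 log units; beyond the scatter) and so moves the number beyond the usual scatter, which the one earlier step, at a different place, did not do. This shows that the methyl on an oxygen next to a carbonyl group is a place where a small edit can register in this cell test, though the step is only modest. The data shown offer no explanation for this step.

On these data alone, it remains open whether a carboxamide or a longer ester such as ethoxycarbonyl at this place would give a number like that of compound 3. Also open, as far as these compounds go, is whether the same change would give a similar step with methyl in place of the (tert-butyl)amino group.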